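The compounds below may be only part of what the source reports. "The series", "measured", "known", "first", "only" and "open" are said of these compounds alone.

Working notes on the series.

The shared core carries a hexanoyl-substituted aryl ether joined through a propyl chain to a piperazine; the compounds differ only in the group on the second piperazine nitrogen. Compound 1 `CCCCCC(=O)c1ccc(OCCCN2CCN(C(=O)OC)CC2)cc1` bears a methoxycarbonyl there and in an assay on isolated protein for binding affinity to histamine H2 receptor (Homo sapiens) (a higher number here means a weaker inhibitor, a lower number a stronger inhibitor), compound 1 gives 12000 nM. Compound 2 `CCCCCC(=O)c1ccc(OCCCN2CCN(C(=O)N3CCOCC3)CC2)cc1` carries a (morpholin-4-yl)carbonyl; in this assay compound 2 gives 17800 nM. The step of a 1.5-fold higher number from compound 1 to compound 2 (0.17 log units; within the scatter) shows that exchanging the small carbamate for the morpholine urea left the binding essentially where it was. Within the data shown here, compound 2 thus has the higher of the two numbers so far, but the gap to compound 1 is within the scatter, so no order between them can be read.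

Compound 3 `CCCCCC(=O)c1ccc(OCCCN2CCN(S(=O)(=O)c3ccc(C#N)cc3)CC2)cc1` is the next member: (4-cyanophenyl)sulfonyl in place of (morpholin-4-yl)carbonyl on an amine nitrogen in a ring. Among the measured compounds shown here, only the step from compound 1 to compound 2 bears on this position, and it was within the scatter, so there is no measured evidence that the group on this nitrogen moves the number much. The sulfonyl replacement is larger than that earlier swap, so a wider range is allowed. For compound 3 the expected step is a 1.2-fold lower number from compound 2 to compound 3 (0.07 log units; within the scatter), with little change beyond the scatter anticipated. Compound 3 is estimated at 15000 nM, in the range 5000 nM to 45000 nM.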

Compound 3, inhibition constant: 12300 nM
Beside the measured number, compound 3's estimate is 1.2-fold (0.09 log units) above it; the range from low to high includes it.
By their numbers in this assay, from the lowest: compounds 1, 3 and 2 (each within the scatter of the next).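

The exchange of (morpholin-4-yl)carbonyl for (4-cyanophenyl)sulfonyl on the amine nitrogen in a ring gives a 1.4-fold lower number from compound 2 to compound 3 (0.16 log units; within the scatter) in this assay, and the exchange of methoxycarbonyl for the same group gives a 1.0-fold higher number from compound 1 to compound 3 (0.01 log units; within the scatter). The earlier pair covered only carbonyl-linked groups, whereas these steps show that a sulfonyl link and a six-membered aromatic ring of carbon only bearing a nitrile are also accommodated at this position, with all three pairs remaining within the scatter despite the larger group of 11 heavy atoms. No measurement on hand offers an explanation for this flat result.

Still open, as far as these compounds go, is whether a group on this nitrogen of a different kind, such as a free amine, a carboxylic acid or a plain alkyl chain with neither carbonyl nor sulfonyl link, would give a step beyond the scatter. All three compounds also keep the hexanoyl group and the propyl chain of the shared core, so the contribution of either part, for example against a shorter acyl chain, cannot be read from them.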